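The compounds below may be only part of what the source reports. "The series", "measured", "known", "first", "only" and "open" are said of these compounds alone.

Of the compounds shown here, two built on one shared core have been measured in an assay on CHO cells for binding affinity to metabotropic glutamate receptor 2 (Rattus norvegicus); a lower number here means a stronger inhibitor, a higher number a weaker inhibitor. Compound 1 `N[C@]1(C(=O)O)[C@H]2[C@@H](C[C@H]1OCCCc1ccccc1)[C@]2(F)C(=O)O` gives 9.83 nM. Compound 2 `N[C@]1(C(=O)O)[C@H]2[C@@H](C[C@H]1OCc1c(F)cccc1F)[C@]2(F)C(=O)O` gives 7.02 nM, the smaller of the two recorded numbers, although the step of a 1.4-fold lower number from compound 1 to compound 2 (0.15 log units; within the scatter) lies within the scatter, so the two cannot be told apart. Compound 3 `N[C@]1(C(=O)O)[C@H]2[C@@H](C[C@H]1OCc1cc(Cl)ccc1Cl)[C@]2(F)C(=O)O` has not been measured yet; it differs from compound 2 by 2,5-dichlorophenyl in place of 2,6-difluorophenyl on a saturated chain carbon bound to an oxygen on a saturated carbon. Going by the values given here, the one measured step that bears on this change is the one from compound 1 to compound 2, which also exchanged the aromatic group on that carbon, and it was small. With both measured values sitting close together, the expected step is a 1.1-fold higher number from compound 2 to compound 3 (0.06 log units; within the scatter), meaning no change beyond the scatter in this assay. Compound 3 is therefore estimated at 8 nM, with a likely range from 3 nM to 22 nM.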

Compound 3, inhibition constant: 11.8 nM
The estimate for compound 3 lay 1.5-fold (0.17 log units) below the measured number; measured number inside the range.
By their numbers in this assay, from the lowest: compounds 2, 1 and 3 (each within the scatter of the next).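

In this assay putting 2,5-dichlorophenyl in place of 2,6-difluorophenyl gives a 1.7-fold higher number from compound 2 to compound 3 (0.23 log units; within the scatter) and putting it in place of phenethyl gives a 1.2-fold higher number from compound 1 to compound 3 (0.08 log units; within the scatter) on the same saturated chain carbon bound to an oxygen. Where the earlier pair offered one exchange at this position, three groups can now be compared, and they include a ring carrying chlorine instead of fluorine; all three compounds remain within the scatter of one another, so the numbers cannot tell them apart. No supporting measurement is available to explain this closeness.

The compounds shown leave open whether this position would stay as undiscriminating with a group of another kind, such as an amine, a carboxylic acid or a longer chain. They also leave open whether a ring without halogens, such as an unsubstituted phenyl or a pyridine, would fall within the same scatter.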